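Swapping the Ring at the End of the Side Chain

The source may hold more compounds than are shown below. What is called first, only, known or untested is meant among the compounds shown, and "the series" means these compounds.

Compound 1, `COc1ncc(-c2ccc3nc(NC(=O)NCCN4CCCCC4)sc3c2)cc1NS(=O)(=O)c1ccc(F)cc1`: 450 nM
Compound 2, `CCN(CC)CCNC(=O)Nc1nc2ccc(-c3cnc(OC)c(NS(=O)(=O)c4ccc(C)cc4)c3)cc2s1`: 170 nM
Compound 3, `CCN(CC)CCNC(=O)Nc1nc2ccc(-c3cnc(Cl)c(NS(=O)(=O)c4ccc(F)cc4)c3)cc2s1`: 710 nM

All three compounds were tested in a functional assay on MCF7 cells (Homo sapiens) for antiproliferative activity, read by MTT assay, with a stated time of 72 h; on this read-out higher numbers stand for weaker inhibition and lower numbers for stronger inhibition. On this measure compound 1, with 450 nM, holds the second-highest of the three numbers. Compound 3 sits nearest, with 710 nM, its higher number lying within the usual scatter, so the two cannot be told apart. Compound 2 sits furthest, with 170 nM, its lower number lying beyond the scatter, so compound 2 holds back cell growth more strongly than compound 1.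

Compound 4, `COc1ncc(-c2ccc3nc(NC(=O)NCCN4CCN(C)CC4)sc3c2)cc1NS(=O)(=O)c1ccc(F)cc1`, differs from compound 1 in one place only: 4-methylpiperazin-1-yl in place of piperidin-1-yl on a saturated chain carbon, two bonds along the chain from an amide-type nitrogen. Within the data shown here, no pair among the measured compounds differs in just this way, so the size of this step has not been observed. The rest of the molecule is kept as in compound 1. The step from compound 1 to compound 4 in this assay is expected to be small, in either direction, and not beyond the scatter. Compound 4 is therefore estimated at 500 nM, with a likely range from 200 nM to 1300 nM, which is expected to amount to a step of a 1.1-fold higher number from compound 1 to compound 4 (0.05 log units; within the scatter).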

Compound 4, half-maximal inhibitory concentration: 470 nM
For compound 4 the middle estimate is 1.1-fold (0.03 log units) above the measured one; measured number inside the range.
By their numbers in this assay, from the lowest: compound 2; then compounds 1, 4 and 3 (each within the scatter of the next).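

Among these compounds, compound 1 and compound 4 are the first pair here that differ only in the ring at the end of the side chain, and in this assay the comparison reads a 1.0-fold higher number from compound 1 to compound 4 (0.02 log units; within the scatter) and so does not separate them. At this place, on a saturated chain carbon, two bonds along the chain from an amide-type nitrogen, a ring with 2 hetero atoms and 7 heavy atoms therefore serves as well as one with 1 hetero atom and 6 heavy atoms, at least on the core of compound 1 and in this cell assay. No measurement at hand speaks to why these two rings give such similar numbers.

This single pair cannot show how far the tolerance extends, for instance whether a morpholin-4-yl ring, a simple primary amine or a carboxylic acid at the chain end, or a longer chain between the urea and the ring, would fit equally well. It also leaves open whether the same swap would read alike on the chloro-substituted or methyl-substituted partners seen in compound 3 and compound 2.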